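A Methyl Group on a Nitrogen of Compound 1

The source may report more compounds than this note shows. Statements on the series, on what has been measured and on what is new or still open speak of the compounds shown alone.

In a functional assay on MV4-11 cells (Homo sapiens) for antiproliferative activity, read by MTT assay (a lower number here means a stronger inhibitor of growth, a higher number a weaker inhibitor of growth), compound 1 `COc1ccc(Nc2nc(NC3CCCC3)c3ccccc3n2)cc1` gives 4910 nM, compound 2 `COc1ccc(Nc2nc(NCCCO)c3ccccc3n2)cc1` gives 8750 nM and compound 3 `CCCNc1nc(Nc2ccc(OC)cc2)nc2ccccc12` gives 5880 nM. Compound 1 therefore stands level with both of the others. Compound 4 `COc1ccc(N(C)c2nc(NC3CCCC3)c3ccccc3n2)cc1` differs from compound 1 in one place: methyl in place of hydrogen on a nitrogen on an aromatic ring. Among the compounds with values here, no measured step touches this nitrogen. The closest evidence replaces the cyclopentyl group instead, with a 1.2-fold higher number from compound 1 to compound 3 (0.08 log units; within the scatter) and a 1.8-fold higher number from compound 1 to compound 2 (0.25 log units; within the scatter), both within the scatter. Going by these compounds, these steps say little about the new methyl, so no shift beyond the scatter is firmly expected in this assay, and either direction stays open. The expected step is a 1.0-fold higher number from compound 1 to compound 4 (0.01 log units; within the scatter). Compound 4 is estimated at 5000 nM, within an expected range of 1800 nM to 14000 nM.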

Compound 4, concentration for 50% growth inhibition: 2700 nM
Estimate against measurement, compound 4: 1.9-fold (0.27 log units) above; low and high end bracket the measured number.
By their numbers in this assay, from the lowest: compounds 4, 1, 3 and 2 (each within the scatter of the next, the first and the last beyond it).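

In this assay, methyl in place of hydrogen on a nitrogen on an aromatic ring gives a 1.8-fold lower number from compound 1 to compound 4 (0.26 log units; within the scatter) and so stays within the scatter. Within the data shown here, this is the first look at this nitrogen, as the earlier steps changed only the group on the other nitrogen, and it shows that the hydrogen here can be replaced by methyl without a shift beyond the scatter. Nothing shown explains the result. Going by these compounds, whether an ethyl group, a longer chain or an acetyl group on this nitrogen would also stay level remains open. So does the effect of this methyl when the cyclopentyl group is replaced.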